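Second trifluoromethyl on compound 2: working notes

The source may hold more compounds than are shown below. What is called first, only, known or untested is meant among the compounds shown, and "the series" means these compounds.

Measured in a functional assay on DU-145 cells (Homo sapiens) for antiproliferative activity, read by propidium iodide staining, with a stated time of 96 h; on this read-out higher numbers stand for weaker inhibition and lower numbers for stronger inhibition:
Compound 1 `CC(O)(COc1cccc(S(F)(F)(F)(F)F)c1)C(=O)Nc1ccc(S(F)(F)(F)(F)F)cc1`: 29600 nM
Compound 2 `CC(O)(COc1cccc(C(F)(F)F)c1)C(=O)Nc1ccc(S(F)(F)(F)(F)F)cc1`: 21900 nM

In this assay compound 2 stands at 21900 nM, within the scatter of compound 1. Compound 3 `CC(O)(COc1cc(C(F)(F)F)cc(C(F)(F)F)c1)C(=O)Nc1ccc(S(F)(F)(F)(F)F)cc1` has trifluoromethyl in place of hydrogen on an aromatic carbon. Among the measured compounds shown here, the only measured step, a 1.4-fold lower number from compound 1 to compound 2 (0.13 log units; within the scatter), exchanges one group for another and stays within the scatter. For the measured compounds named here, no measured step adds a group in place of hydrogen, so the evidence is thin, and no shift beyond the scatter is expected. The estimated change is a 1.2-fold lower number from compound 2 to compound 3 (0.09 log units; within the scatter). The estimate for compound 3 is 18000 nM, with an expected range of 7000 nM to 40000 nM.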

Compound 3, half-maximal inhibitory concentration: 8600 nM
Beside the measured number, compound 3's estimate is 2.1-fold (0.32 log units) above it; measured number inside the range.
By their numbers in this assay, from the lowest: compound 3; then compounds 2 and 1 (each within the scatter of the next).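

In this assay, among the compounds shown here, trifluoromethyl in place of hydrogen on this aromatic carbon gives a 2.5-fold lower number from compound 2 to compound 3 (0.41 log units; beyond the scatter), the first step to lie beyond the scatter. The earlier exchange of one group for another did not. Filling this position in compound 2 therefore changes the read-out, while nothing available bears on the reason for the shift.

Going by these compounds, compound 3 is the only case of substitution here, so it remains open whether an amine, a methoxy group or chlorine on this carbon would shift the number likewise.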